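This account rests on a few compounds, and the source may have more. Where it says the series, first, only, none or still open, it means among the compounds named here.

Working notes on the series.

The series shares one core; compound 1 `O=C(N/N=C/c1cccc(Cl)c1)c1cnccn1` carries chloro on the aromatic ring. In an ADME assay on J774 cells (Mus musculus) for cytotoxicity, read by MTT assay, with a stated time of 48 h, tested at 150 ug/mL (a lower number here means a stronger effect, a higher number a weaker effect of the compound at the concentration tested), compound 1 gives 100%, the highest of the three numbers obtained. Compound 2 `O=C(N/N=C/c1ccc(Cl)cc1)c1cnccn1` gives 56% in this assay, a number well beyond the scatter away from compound 1, and compound 3 `O=C(N/N=C/c1ccccc1O)c1cnccn1` gives 0%, the furthest from compound 1. Among the compounds with values here, no single-site pair among the measured compounds is available, so nothing is known yet of how one change on the ring shifts the number.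

Compound 4 `N#Cc1cccc(/C=N/NC(=O)c2cnccn2)c1` is the next member to be measured. Relative to compound 1 the change is cyano in place of chloro on an aromatic carbon, on an aromatic carbon of a six-membered aromatic ring of carbon only, meta to a large group. No measured compound carries cyano, so the step size rests on the spread shown by compounds 1, 2 and 3 alone. The step of a number 15 percentage points lower from compound 1 to compound 4 (beyond the scatter) is expected to be modest and, if anything, downward from compound 1 because compound 1 gives 100%. For compound 4 the estimate in this assay is 85%, within a range from 55% to 100%.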

Compound 4, a percentage reported as activity, at one concentration (the size of the read-out at that concentration, not a potency): 100%
Estimate against measurement, compound 4: 15 percentage points below, and the stated range covers the measured number.
By their numbers in this assay, from the lowest: compound 3; then compound 2; then compounds 1 and 4 (each within the scatter of the next).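

Within the data shown here, compounds 1 and 4 form the first single-site pair of the series, and in this assay cyano in place of chloro on an aromatic carbon, meta to a large group, gives no change at the digits printed from compound 1 to compound 4 (within the scatter) at the one concentration tested. At this place, the read-out therefore does not separate the two groups, even though cyano brings one more heavy atom, a triple bond and a hydrogen-bond acceptor. Nothing measured here bears on why the two groups read alike.

On these data alone, whether an amine, a carboxylic acid or a longer chain at this same place would leave the number unchanged remains open. Also open, as far as these compounds go, is whether cyano in place of chloro would read the same at another place on the ring.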